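Methyl for methoxy at the limit of the assay

This account rests on a few compounds, and the source may have more. Where it says the series, first, only, none or still open, it means among the compounds named here.

Measured in a toxicity assay on MCF7 cells (Homo sapiens) for cytotoxicity, read by MTT assay, with a stated time of 3 h; a higher number here means a weaker inhibitor, a lower number a stronger inhibitor:
- Compound 1 `COc1ccc2c(c1)CCc1c(-c3ccccc3)c3n(c1-2)[B-](F)(F)[N+]1=C(c2ccc(C)cc2)C(Br)=C(c2ccccc2)C1=N3`: > 50000 nM (a limit)
- Compound 2 `COc1ccc(C2=[N+]3C(=Nc4c(-c5ccccc5)c5c(n4[B-]3(F)F)-c3ccc(OC)cc3CC5)C(c3ccccc3)=C2I)cc1`: > 50000 nM (a limit)

Compound 2 stands at > 50000 nM in this assay, and this is a limit, not a number. The same holds across the measured pair, as the record shows (the limit of > 50000 nM in this assay, at which 2 of the 2 values shown sit). Within the data shown here, no number is therefore available for either compound, and no step between measured compounds can be read.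

Compound 3 `COc1ccc2c(c1)CCc1c(-c3ccccc3)c3n(c1-2)[B-](F)(F)[N+]1=C(c2ccc(C)cc2)C(I)=C(c2ccccc2)C1=N3` is the next to be measured. Relative to compound 2, it carries methyl in place of methoxy on an aromatic carbon, para to a large group, so that 4-methoxyphenyl becomes 4-methylphenyl: methyl in place of methoxy on an aromatic carbon.

No shift beyond the usual scatter is expected in this assay, and no direction is favoured. The expectation rests on compound 2, whose reading is the limit > 50000 nM. The expected change is a number no higher from compound 2 to compound 3 (the limit leaves the size open). For compound 3 the estimated value is 50000 nM, with an expected range from 25000 nM to 100000 nM. A report as a limit is considered the likeliest outcome.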

Compound 3, half-maximal inhibitory concentration: > 50000 nM
Compound 3 ended at the assay's limit; the forecaster's own chance of this, stated with the estimate: 85%; the middle value lies on the limit itself.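

Compound 3 reads > 50000 nM in this assay, a limit and not a number, so neither step, from compound 1 or from compound 2 to compound 3, can be read. All three compounds share that reading: the limit of > 50000 nM in this assay, at which 3 of the 3 values shown sit.

Left open is whether methyl in place of methoxy, or iodo in place of bromo, changes cytotoxicity on this shared core at all.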